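Thiosemicarbazide series: morpholine in place of thiomorpholine

This account rests on a few compounds, and the source may have more. Where it says the series, first, only, none or still open, it means among the compounds named here.

Of the compounds shown here, three of a shared amidrazone-thiosemicarbazide core have been measured in a functional assay on HeLa cells (Homo sapiens) for cytotoxicity, read by MTT assay, with a stated time of 72 h; on this read-out lower numbers stand for stronger inhibition and higher numbers for weaker inhibition. Compound 1 `Cc1ccnc(/C(N)=N/NC(=S)N2CCSCC2)c1` gives 15500 nM, the highest number of the three and the weakest inhibition recorded so far. Compound 2 `Cc1cccc(/C(N)=N/NC(=S)N2CCCCC2)n1` gives 2000 nM in this assay, and compound 3 `N/C(=N\NC(=S)N1CCN(c2ccccn2)CC1)c1ccc(F)cn1` gives 2000 nM in this assay; both stand beyond the usual scatter below compound 1, and the two of them lie within the scatter of each other, so no order between compounds 2 and 3 can be read. Going by the values given here, compounds 2 and 3 differ from compound 1 in more than one place, so no single step between measured compounds is available.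

Compound 4 `Cc1ccnc(/C(N)=N/NC(=S)N2CCOCC2)c1` has not yet been measured in this assay. It differs from compound 1 in one place: morpholin-4-yl in place of thiomorpholin-4-yl on a thiocarbonyl carbon. Among the compounds with values here, with no measured step of this kind to lean on, the expectation is that the step from compound 1 to compound 4 in this assay stays within the scatter, in either direction, as a 1.1-fold higher number from compound 1 to compound 4 (0.04 log units; within the scatter). Compound 4 is therefore estimated at 17000 nM in this assay, with a range from 6000 nM to 50000 nM.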

Compound 4, half-maximal inhibitory concentration: 38500 nM
Beside the measured number, compound 4's estimate is 2.3-fold (0.36 log units) below it, within the range that was stated.
By their numbers in this assay, from the lowest: compounds 2 and 3 (each within the scatter of the next); then compound 1; then compound 4.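

The ring atom at this position is not silent: in this assay, morpholin-4-yl in place of thiomorpholin-4-yl on a thiocarbonyl carbon gives a 2.5-fold higher number from compound 1 to compound 4 (0.40 log units; beyond the scatter), a modest step but one beyond the scatter, and the only one-place comparison among the compounds shown. The two groups match in heavy-atom count, ring size, hydrogen-bond donors and acceptors, and net charge, and they part only in carrying oxygen or sulfur in the ring, so these counts do not separate them, yet the exchange of that one ring atom is enough to shift the number. Nothing at hand bears on why the morpholine-bearing compound gives the higher number, and the step stands without an explanation.

As far as these compounds go, whether the same exchange shifts the number in the same direction on the cores of compound 2 and compound 3 stays open, as no one-place step can be read for either of them. Also open, from the compounds shown here alone, is how an open-chain group such as dimethylamino or diethylamino on the thiocarbonyl carbon would stand against the two rings on the core of compound 1.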